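A Longer Acid Chain From Compound 2 to Compound 4

A few compounds are considered here, and "the series" means these few. Any claim that something is new, unique, unknown or untested is made for them only; others in the source may bear on it.

The study measures an assay on isolated protein for binding affinity to prostaglandin E2 receptor EP1 subtype (Mus musculus); on this read-out lower numbers stand for stronger inhibition and higher numbers for weaker inhibition. Compound 1 `CCCCOc1cccc(C(=O)n2c(C)c(CC(=O)O)c3cc(OC)ccc32)c1` returns only a limit there, > 10000 nM. Compound 2 `CCCCOc1ccc(C(=O)n2c(C)c(CC(=O)O)c3cc(OC)ccc32)cc1` likewise reaches only the limit of this assay, > 10000 nM. Among the measured compounds shown here, compound 3 `CCCCOc1ccc(C(=O)n2c(CCC)c(C(=O)O)c3cc(OC)ccc32)cc1` is the single member with a true number, 3800 nM. Compound 2 therefore stands at the weak end of what is shown, sharing its limit with compound 1; the limit of > 10000 nM in this assay, at which 2 of the 3 values shown sit, marks where two of the three values sit.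

Compound 4 `CCCCOc1ccc(C(=O)n2c(C)c(CCCCC(=O)O)c3cc(OC)ccc32)cc1` has not been measured. It differs from compound 2 in one place: 3-carboxypropyl in place of carboxy on a saturated chain carbon bound to an aromatic carbon. In words, 3-carboxypropyl takes the place of carboxy on a saturated chain carbon bound to an aromatic carbon, so the acid now sits at the end of a longer flexible chain.

For the measured compounds named here, no step between measured compounds shows what such a lengthening does in this assay, and since compound 2 itself gives only a limit, any expectation rests on thin ground. A small gain, or no change beyond the usual scatter, seems the likeliest outcome, with a fair chance that only a limit is reported again. Compound 4 is expected at 6000 nM, within 1500 nM to 30000 nM. The estimated step of an at least 1.6-fold lower number from compound 2 to compound 4 (0.22 log units; that floor lies within the scatter) is thus modest and uncertain.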

Compound 4, inhibition constant: > 10000 nM
Compound 4 ended at the assay's limit (the forecaster's own chance of this, stated with the estimate: 55%); middle value at least 1.6-fold (0.22 log units) from the limit.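

In this assay compound 4 gives > 10000 nM, which is a limit and not a number. Among the compounds shown here, compound 2 also gives only a limit, so no step between compound 2 and compound 4 can be read. Whether 3-carboxypropyl in place of carboxy changes the affinity at all stays open, since both compounds sit at the same mark: the limit of > 10000 nM in this assay, at which 3 of the 4 values shown sit.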